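The source may report more compounds than this note shows. Statements on the series, on what has been measured and on what is new or still open speak of the compounds shown alone.

In a functional assay on MCF7 cells (Homo sapiens) for inhibition (on this read-out higher numbers stand for weaker inhibition and lower numbers for stronger inhibition), three compounds have been measured, and each is weak on this read-out. Compound 1 `CCC(C)C(NC(=O)NO)C(=O)NC(c1ccccc1)c1ccccc1` gives 17800 nM. Compound 3 `CCC(C)C1NC(=O)N(Cc2ccccc2)C1=O` gives 29500 nM. Compound 2 `CCC(C)C1NC(=O)N(C2CCCC2)C1=O` gives 67400 nM, the highest of the three numbers; the gap to compound 3, its nearest neighbour, lies beyond the scatter, and the gap to compound 1 is larger still. No pair among these three differs in a single place, so no measured step can be carried over to the change now at hand.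

Compound 4 `O=C1NC(c2ccccc2)C(=O)N1C1CCCC1` differs from compound 2 in one place only: phenyl in place of sec-butyl on a saturated ring carbon. For the measured compounds named here, nothing among the measured compounds shows what a phenyl in that position does, so the direction of the step in this assay is open. Since compound 2 sits at the weak end with 67400 nM, and the other two compounds with the shared core lie below it, the estimate leans toward a modest improvement, with wide uncertainty around it. The step of a 1.3-fold lower number from compound 2 to compound 4 (0.13 log units; within the scatter) is the one expected, small in size and not certain to exceed the scatter. Compound 4 is expected to give about 50000 nM, within a range from 15000 nM to 160000 nM.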

Compound 4, half-maximal inhibitory concentration: 22000 nM
For compound 4 the middle estimate is 2.3-fold (0.36 log units) above the measured one; measured number inside the range.
By their numbers in this assay, from the lowest: compounds 1, 4 and 3 (each within the scatter of the next); then compound 2.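

In this assay, putting phenyl in place of sec-butyl on the saturated ring carbon gives a 3.1-fold lower number from compound 2 to compound 4 (0.49 log units; beyond the scatter), the first step measured at this position, and it shows that inhibition here depends on the group this carbon carries. With the cyclopentyl group held constant, an aromatic ring on this carbon goes with stronger inhibition than the open sec-butyl chain, although the step is modest and compound 4 still gives only 22000 nM on this read-out. Nothing at hand explains why the phenyl does better than the sec-butyl on this carbon.

The compounds shown leave open whether the gain belongs to the aromatic ring itself or merely to the larger count of carbons, which a cyclohexyl group or a longer chain such as n-hexyl on the same carbon could separate, and whether a phenyl carrying an amine or a carboxylic acid would go further. Also open, on these data alone, is whether the same step would hold with the benzyl group of compound 3 in place of the cyclopentyl group.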